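Urea series on the shared core: piperidine for piperazine

This account rests on a few compounds, and the source may have more. Where it says the series, first, only, none or still open, it means among the compounds named here.

Measured compounds:
compound 1 `CNC(=O)c1cc(Oc2ccc3nc(NC(=O)c4ccc(Cl)cc4Cl)sc3c2)ccn1`, 15.1%
compound 2 `CNC(=O)c1cc(Oc2ccc3nc(NC(=O)Nc4ccc(N5CCN(C)CC5)cc4)sc3c2)ccn1`, 24.6%

In a functional assay on HCT-116 cells (Homo sapiens) for inhibition, read by MTT assay, with a stated time of 2 days, tested at 10 uM (a higher number here means more inhibition of growth at the concentration tested, a lower number less inhibition of growth), compound 2 gives 24.6%, and compound 1 gives 15.1%; the two values lie within the scatter of each other, so the two compounds are not separated on the numbers at hand. Among the measured compounds shown here, no pair of measured compounds differs in only one place, so no counted step is available.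

Compound 3 `CNC(=O)c1cc(Oc2ccc3nc(NC(=O)Nc4ccc(C5CCN(C(C)C)CC5)cc4)sc3c2)ccn1` differs from compound 2 by 1-isopropylpiperidin-4-yl in place of 4-methylpiperazin-1-yl on an aromatic carbon. Both compounds keep the urea link to the shared core. With the two measured values standing so close together, there is no basis for a step in either direction beyond the scatter. The expected step from compound 2 to compound 3 in this assay is therefore a number 0.4 percentage points higher from compound 2 to compound 3 (within the scatter), that is, no change beyond the scatter. For compound 3 in this assay the estimate is 25%, with a range from 5% to 50%.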

Compound 3, percent growth inhibition at one concentration: 68.1%
For compound 3 the middle estimate is 43.1 percentage points below the measured one; measured number outside the range, above it.
By their numbers in this assay, from the lowest: compounds 1 and 2 (each within the scatter of the next); then compound 3.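

In this assay, among the compounds shown here, 1-isopropylpiperidin-4-yl in place of 4-methylpiperazin-1-yl gives a number 43.5 percentage points higher from compound 2 to compound 3 (beyond the scatter), a large step and the only counted step so far. This position, on an aromatic carbon para to a large group, is therefore not indifferent to the group it carries, at least for this change with the urea link kept. No measurement at hand bears on what lies behind a step of this size.

The change alters both the ring and the alkyl group on its nitrogen, so the compounds shown do not separate the two: 1-methylpiperidin-4-yl and 4-isopropylpiperazin-1-yl would each change only one. From the compounds shown here alone, whether the step persists with an unsubstituted piperidin-4-yl or with a longer chain on that nitrogen also remains open.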